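The source may report more compounds than this note shows. Statements on the series, on what has been measured and on what is new or still open speak of the compounds shown alone.

Measured so far in a functional assay on HeLa cells (Homo sapiens) for inhibition, read by MTT assay, with a stated time of 48 h (a higher number here means a weaker inhibitor, a lower number a stronger inhibitor), for this series:
- compound 1 `Oc1ccc(C(c2c[nH]c3ccc(Br)cc23)c2c[nH]c3ccc(Br)cc23)cc1` gives 4000 nM
- compound 2 `Oc1cccc(C(c2c[nH]c3ccc(Br)cc23)c2c[nH]c3ccc(Br)cc23)c1` gives 3900 nM
- compound 3 `COc1ccc(C(c2c[nH]c3ccc(Br)cc23)c2c[nH]c3ccc(Br)cc23)cc1` gives 5500 nM

Compound 3 stands level with the other two: a 1.4-fold higher number from compound 1 to compound 3 (0.14 log units; within the scatter) and a 1.4-fold higher number from compound 2 to compound 3 (0.15 log units; within the scatter) are both within the scatter, so no order can be read among the three.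

Compound 4 `COc1cccc(C(c2c[nH]c3ccc(Br)cc23)c2c[nH]c3ccc(Br)cc23)c1OC` keeps the shared core and is not yet measured. Its difference from compound 3 is 2,3-dimethoxyphenyl in place of 4-methoxyphenyl on a saturated chain carbon bound to two aromatic carbons in full, 2,3-dimethoxyphenyl in place of 4-methoxyphenyl on a saturated chain carbon bound to two aromatic carbons.

Going by the values given here, three measured steps bear on this change. Moving the hydroxyl group gives a 1.0-fold lower number from compound 1 to compound 2 (0.01 log units; within the scatter) and adding methyl on the oxygen gives a 1.4-fold higher number from compound 1 to compound 3 (0.14 log units; within the scatter) as the two closest cases, with a 1.4-fold higher number from compound 2 to compound 3 (0.15 log units; within the scatter) as the third, and all of them are small. Among the compounds with values here, no measured compound carries two methoxy groups, so that part of the change is untested. On this evidence no shift beyond the scatter is expected in this assay and no direction can be given.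

The expected step is a 1.1-fold lower number from compound 3 to compound 4 (0.04 log units; within the scatter) and it stays within the scatter. For compound 4 the estimated value is 5000 nM with an expected range from 2200 nM to 11000 nM for a single measurement.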

Compound 4, half-maximal inhibitory concentration: 64500 nM
Beside the measured number, compound 4's estimate is 13-fold (1.11 log units) below it; measured number outside the range, above it.
By their numbers in this assay, from the lowest: compounds 2, 1 and 3 (each within the scatter of the next); then compound 4.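

In this assay, going by these compounds alone, the group on the saturated chain carbon bound to two aromatic carbons proves not to be indifferent: 2,3-dimethoxyphenyl in place of 4-methoxyphenyl gives a 12-fold higher number from compound 3 to compound 4 (1.07 log units; beyond the scatter) and is the first step to lie beyond the scatter. Set against the two hydroxyphenyl compounds, the same group gives a 17-fold higher number from compound 2 to compound 4 (1.22 log units; beyond the scatter) and a 16-fold higher number from compound 1 to compound 4 (1.21 log units; beyond the scatter) so that compound 4 is the weakest of the four, whereas the changes among compound 1, compound 2 and compound 3 all stayed within the scatter. Nothing available bears on why the number rises at this position.

As far as these compounds go, whether the rise follows from the added methoxy group alone or from where the two methoxy groups sit stays open, as compound 4 carries both changes at once. Also open, from the compounds shown here alone, is how this position responds to two hydroxyl groups in place of the two methoxy groups, or to a group of another kind on the same ring, such as an amine or a carboxylic acid.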